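Chain branching from compound 3 to compound 4

The source may hold more compounds than are shown below. What is called first, only, known or untested is meant among the compounds shown, and "the series" means these compounds.

Compound 1 `CCCOC(=O)C1=C(C)NC(=O)NC1c1cccs1` gives 32% in an assay on membranes from HeLa cells for displacement of a labelled ligand from adenosine receptor A3 (Homo sapiens), read by scintillation counting, with a stated time of 180 min, tested at 1 uM; a lower number here means less inhibition, a higher number more inhibition at the concentration tested (going by the name of the read-out). Compound 2 `CC1=C(C(=O)OCC(C)C)C(c2cccs2)NC(=O)N1` differs from it by methyl in place of hydrogen on a saturated chain carbon bound to two saturated chain carbons and gives 11% in this assay, which amounts to a number 21 percentage points lower from compound 1 to compound 2 (beyond the scatter). Compound 3 `CCCOC(=O)C1=C(C)N(C)C(=O)NC1c1ccoc1` is built on another core; the difference between the two cores is not broken down here. In this assay compound 3 gives 16%, within the scatter of compound 2 and beyond the scatter below compound 1.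

Compound 4 `CC1=C(C(=O)OCC(C)C)C(c2ccoc2)NC(=O)N1C` is not yet measured. It differs from compound 3 by methyl in place of hydrogen on a saturated chain carbon bound to two saturated chain carbons, the same change as from compound 1 to compound 2, with the place described in identical words. Within the data shown here, only that one earlier instance exists, and it sits on a different core, so the transfer is uncertain. Because of a number 21 percentage points lower from compound 1 to compound 2 (beyond the scatter) the same change is expected to lower the number again. Compound 3 stands at 16%, so the room below is small, and for compound 4 a step of a number 10 percentage points lower from compound 3 to compound 4 (within the scatter) is expected. Compound 4 is therefore estimated at 6%, between 0% and 16%.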

Compound 4, a percentage reported as inhibition, at one concentration (the size of the read-out at that concentration, not a potency): 16%
The estimate for compound 4 lay 10 percentage points below the measured number, and the stated range covers the measured number.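

Carrying the change from propyl to isobutyl in the ester chain from one core to another is not reliable in this series, as the two instances differ: the same change on two cores in this assay, a number 21 percentage points lower (beyond the scatter) from compound 1 to compound 2 and no change at the digits printed (within the scatter) from compound 3 to compound 4, 21 percentage points apart, beyond the scatter of two such steps.

On the core of compound 3, the change gives no change at the digits printed from compound 3 to compound 4 (within the scatter) in this assay and so does not repeat the lowering seen on the core of compound 1. These two pairs do not show which difference between the cores decides the outcome, and with one pair per core they give no rule for any further core.

Open, on these data alone, is how the ester chain behaves beyond propoxy and isobutoxy on either core, for instance with a longer chain such as pentyloxy or with benzyloxy. Also open, as far as these compounds go, is whether the same contrast between the cores would appear in a potency measure, as the read-out here is inhibition at a single concentration.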